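This account rests on a few compounds, and the source may have more. Where it says the series, first, only, none or still open, it means among the compounds named here.

Of the compounds shown here, three sharing one core have been measured in an ADME assay on GES1 cells (Homo sapiens) for inhibition, read by MTT assay, with a stated time of 72 h; on this read-out higher numbers stand for weaker inhibition and lower numbers for stronger inhibition. Compound 1 `Cc1cc(Nc2cc(-c3ccccc3)[nH]n2)n2nc(SCc3ccc(C(F)(F)F)cc3)nc2n1` gives 42700 nM in this assay. Compound 2 `CCCSc1nc2nc(C)cc(Nc3cc(-c4ccccc4)[nH]n3)n2n1` reaches only a limit of this assay, > 50000 nM, and no number. Compound 3 `C#CCSc1nc2nc(C)cc(Nc3cc(-c4ccccc4)[nH]n3)n2n1` gives 45700 nM in this assay. Among the two numbers shown, compound 3 is placed by a 1.1-fold higher number from compound 1 to compound 3 (0.03 log units; within the scatter), a gap within the scatter. The remaining steps between these three compounds also stay within the scatter: an at least 1.1-fold higher number from compound 1 to compound 2 (0.06 log units; that floor lies within the scatter) and an at least 1.0-fold lower number from compound 2 to compound 3 (0.03 log units; that floor lies within the scatter), the second of which runs from a limit.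

Compound 4 `COc1ccc(CSc2nc3nc(C)cc(Nc4cc(-c5ccccc5)[nH]n4)n3n2)cc1` has not yet been measured in this assay. It differs from compound 3 in a single place: 4-methoxyphenyl in place of ethynyl on a saturated chain carbon bound to a sulfur. The measured step that bears most directly on this change is the one in which an aryl group gave way to ethynyl on the same saturated chain carbon bound to a sulfur, a 1.1-fold higher number from compound 1 to compound 3 (0.03 log units; within the scatter); the step in which a propyl took that place, an at least 1.1-fold higher number from compound 1 to compound 2 (0.06 log units; that floor lies within the scatter), points the same way. Since an aromatic ring, a short saturated chain and a triple bond at this position all gave numbers within the scatter of one another, the return of an aromatic ring in compound 4 is expected to shift the number little, if at all. The step expected from compound 3 to compound 4 is a 1.0-fold lower number from compound 3 to compound 4 (0.02 log units; within the scatter), within the scatter. Compound 4 is therefore estimated to give 44000 nM in this assay, between 22000 nM and 50000 nM.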

Compound 4, half-maximal inhibitory concentration: 28200 nM
The estimate for compound 4 lay 1.6-fold (0.19 log units) above the measured number, within the range that was stated.
By their numbers in this assay, from the lowest: compounds 4, 1 and 3 (each within the scatter of the next). At a limit, above all of these: compound 2.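

With 4-methoxyphenyl on the saturated chain carbon bound to a sulfur, every step that reaches compound 4 in this assay stays within the scatter: a 1.6-fold lower number from compound 3 to compound 4 (0.21 log units; within the scatter), an at least 1.7-fold lower number from compound 2 to compound 4 (0.24 log units; that floor lies within the scatter) and a 1.5-fold lower number from compound 1 to compound 4 (0.18 log units; within the scatter). Among these compounds, the last of these adds something the earlier compounds did not show, since it changes the aromatic ring itself rather than replacing it: methoxy in place of trifluoromethyl on an aromatic carbon, with the same saturated chain carbon kept, leaves the number within the scatter too, so the four groups seen at this position do not separate from one another. Compound 2 remains a limit of the assay and not a number, so the step to it gives only a floor: the limit of > 50000 nM in this assay, at which 1 of the 4 values shown sits.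

What the compounds shown leave open is whether any group on this chain carbon can give a step beyond the scatter, for instance an amine, a carboxylic acid or a longer chain. They also leave open whether a change away from this position, such as a substituent on the phenyl of the shared core, would do so.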